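Bis-benzylidene diketopiperazine series: A549 cytotoxicity notes

The source may hold more compounds than are shown below. What is called first, only, known or untested is meant among the compounds shown, and "the series" means these compounds.

Measured compounds:
- compound 1, `COc1ccccc1/C=c1/[nH]c(=O)/c(=C\c2ccccc2OC)[nH]c1=O`: "not active" (no number reported)
- compound 2, `C=CCn1c(=O)/c(=C\c2ccc(Cl)c(Cl)c2)[nH]c(=O)/c1=C\c1ccccc1`: "not active" (no number reported)
- compound 3, `C=CCn1c(=O)/c(=C\c2cc(F)ccc2C)[nH]c(=O)/c1=C\c1ccccc1OC`: 4900 nM

Going by the values given here, in a functional assay on A549 cells (Homo sapiens) for cytotoxicity, read by CCK-8 assay, with a stated time of 72 h (on this read-out higher numbers stand for weaker inhibition and lower numbers for stronger inhibition), compound 3 is the only member with a reported number; compound 1 and compound 2 are reported without one. Compound 3 therefore stands alone as the reference point for the series.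

Compound 4, `C=CCn1c(=O)/c(=C\c2ccccc2OC)[nH]c(=O)/c1=C\c1ccccc1OC`, is the next entry. Its change from compound 3 is 2-methoxyphenyl in place of 5-fluoro-2-methylphenyl on a double-bonded chain carbon bound to an aromatic carbon. Among the compounds with values here, no pair among the measured compounds tells how this exchange moves potency. Compound 1 carries the 2-methoxyphenyl group on both sides of the shared core and is reported without activity, which weighs toward weaker inhibition for compound 4, though the two differ in more than one place.

The step of a 2.4-fold higher number from compound 3 to compound 4 (0.39 log units; beyond the scatter) is expected to be a loss beyond the scatter, in the direction of weaker inhibition. For compound 4 the estimated value in this assay is 12000 nM, with a range from 4000 nM to 40000 nM, and a real chance that only a limit is reported.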

Compound 4, half-maximal inhibitory concentration: 22400 nM
Compound 4: middle estimate off by 1.9-fold (0.27 log units), on the low side; the range from low to high includes it.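

In this assay, going by these compounds alone, placing 2-methoxyphenyl in place of 5-fluoro-2-methylphenyl on a double-bonded chain carbon bound to an aromatic carbon gives a 4.6-fold higher number from compound 3 to compound 4 (0.66 log units; beyond the scatter), the first measured step. This position therefore responds to the choice of aryl group, even though both groups count 8 heavy atoms and one six-membered aromatic ring, and the entering group differs in count by one hydrogen-bond acceptor; compound 4 also still gives a number, unlike the two entries reported as not active. Nothing measured here accounts for the size or direction of this step.

The compounds shown do not separate the contribution of the fluorine from that of the methyl in the group that leaves. Going by these compounds, how this position would read with an amine or a carboxylic acid on the aromatic ring also remains open.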